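The source may hold more compounds than are shown below. What is called first, only, known or untested is meant among the compounds shown, and "the series" means these compounds.

Compound 1, `ClCc1ccc(Cn2cnc3c(Cl)ncnc32)cc1`, is the starting point, but in a functional assay on T47D cells (Homo sapiens) for cytotoxicity, read by sulforhodamine B assay, with a stated time of 48 h (on this read-out lower numbers stand for stronger inhibition of growth and higher numbers for weaker inhibition of growth), compound 1 gives "not determined" (no result reported), so it stands on no number of its own. Two neighbours give a sense of where compounds of this type fall. Compound 2, `ClCc1cccc(Cn2cnc3c(Cl)nc(Cl)nc32)c1`, gives 4460 nM in this assay. Compound 3, `ClCc1ccccc1Cn1cnc2ncnc(Cl)c21`, gives 4260 nM in this assay. These two values lie within the usual scatter of each other, so nothing separates them.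

The step from compound 1 to compound 4, `ClCc1ccc(Cn2cnc3c(Cl)nc(Cl)nc32)cc1`, is chloro in place of hydrogen on an aromatic carbon. Going by the values given here, no measured pair differs only in this way, so the size of this step cannot be read from a measured difference. What the data show is that compound 2, which carries two chloro groups on its core, and compound 3, which carries one, sit at values that do not differ beyond the scatter. On that basis the step from compound 1 to compound 4 in this assay is expected to be small, with no direction beyond the scatter, and compound 4 is expected to land near the two measured neighbours. Compound 4 is estimated at 4400 nM in this assay, with a likely range from 1500 nM to 13000 nM.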

Compound 4, concentration for total growth inhibition: 5500 nM
The estimate for compound 4 lay 1.3-fold (0.10 log units) below the measured number; the measured number falls inside the stated range.
By their numbers in this assay, from the lowest: compounds 3, 2 and 4 (each within the scatter of the next).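

Compound 1 has no number in this assay to set against compound 4, so no new step can be read from this result. The compounds shown leave open how much chloro in place of hydrogen on the shared core alters growth inhibition in this assay. No measurement shown here offers an explanation for the value of compound 4.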